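Propynyl to methylimidazolyl on the head-group carbon

A few compounds are considered here, and "the series" means these few. Any claim that something is new, unique, unknown or untested is made for them only; others in the source may bear on it.

Measured so far in a functional assay on HEK293 cells for agonist activity at Free fatty acid receptor 1 (Homo sapiens), read by fluorescence and calcium flux, with a stated time of 10 min; on this read-out higher numbers stand for an effect only at larger amounts of compound and lower numbers for an effect already at smaller amounts:
Compound 1 `CS(=O)(=O)CCCOc1ccc2c(c1)OC(COc1ccc(CCC(=O)O)c(F)c1)CC2` gives 36300 nM.
Compound 2 `COc1ccc2c(c1)OC(COc1ccc(CCC(=O)O)c(F)c1)CO2` gives 1470 nM.
Compound 3 `CC#CC(CC(=O)O)c1ccc(OCC2COc3ccc(Cl)cc3O2)cc1` gives 100 nM.

Compound 3 shows the lowest number of the three. Its gap to compound 2 lies beyond the usual scatter, and its gap to compound 1 lies further still beyond it; compound 3 therefore stands apart as the most potent of the measured set. No two of the three compounds differ in one place only, so none of these gaps can be tied to a single structural change.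

Compound 4 `Cn1cncc1C(CC(=O)O)c1ccc(OCC2COc3ccc(Cl)cc3O2)cc1` is the next compound to be run in this assay . It differs from compound 3 in one place: 1-methyl-1H-imidazol-5-yl in place of prop-1-yn-1-yl on a saturated chain carbon bound to an aromatic carbon and a saturated chain carbon. Among the compounds with values here, no measured pair in this set carries a step of this kind, so the size of the move cannot be read off from the series. The head group with the carboxylic acid and the chlorinated bicyclic ether side stay as in compound 3. For the step from compound 3 to compound 4 a modest loss is expected, a 2.5-fold higher number from compound 3 to compound 4 (0.40 log units; beyond the scatter), possibly within the scatter. For compound 4 the expected value is 250 nM, with a range from 60 nM to 1500 nM.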

Compound 4, half-maximal effective concentration: 3060 nM
Beside the measured number, compound 4's estimate is 12-fold (1.09 log units) below it; measured number above the stated range.
By their numbers in this assay, from the lowest: compound 3; then compound 2; then compound 4; then compound 1.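

In this assay, this position, a saturated chain carbon bound to an aromatic carbon and a saturated chain carbon, proves sensitive to the change: 1-methyl-1H-imidazol-5-yl in place of prop-1-yn-1-yl gives a 31-fold higher number from compound 3 to compound 4 (1.49 log units; beyond the scatter). Within the data shown here, this is the only single-place comparison so far, and it shows that a change at this one carbon, with the rest of the structure held constant, can alone produce a large shift, which the earlier gaps could not show. The entering group brings a five-membered aromatic ring with 2 hetero atoms and 2 hydrogen-bond acceptors, whereas the leaving group has no ring and no acceptors, but no measurement at hand explains the loss or separates these differences.

Among these compounds, the single step leaves open whether the loss follows the ring itself, its nitrogen atoms or its methyl group; a phenyl, a cyclopropyl or an unmethylated imidazolyl group at this carbon would help to separate these. Also open, as far as these compounds go, is whether a smaller alkyne such as ethynyl, or a longer one such as but-1-yn-1-yl, would hold the number of compound 3.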